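The source may hold more compounds than are shown below. What is called first, only, known or untested is meant among the compounds shown, and "the series" means these compounds.

Compound 1 `CCN1CCN(CCCn2cnc3c(N4CCN(CC)CC4)nc(NC(=O)c4ccccc4)nc32)CC1` is the weaker of the two compounds measured in an assay on HEK293 cells for antagonist activity at Toll-like receptor 9 (Homo sapiens), read by spectrophotometry (a lower number here means a stronger inhibitor, a higher number a weaker inhibitor), where compound 1 gives 340 nM, while compound 2 `CCN1CCN(c2nc(NCc3ccc(OC)cc3)nc3c2ncn3CCCN2CCCC2)CC1` in this assay gives 80 nM. Compound 3 `CCN1CCN(CCCn2cnc3c(N4CCN(CC)CC4)nc(NCc4ccc(N(CC)CC)cc4)nc32)CC1` has not yet been measured. It differs from compound 1 in one place: 4-(diethylamino)benzyl in place of benzoyl on a nitrogen on an aromatic ring. Compound 2 also carries a benzyl group on that nitrogen, so a move toward its lower number seems plausible. Compound 3 is therefore expected to give a lower number, an estimated step of a 3.1-fold lower number from compound 1 to compound 3 (0.49 log units; beyond the scatter) beyond the scatter. The estimate for compound 3 in this assay is 110 nM, expected to lie between 40 nM and 300 nM.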

Compound 3, half-maximal inhibitory concentration: 440 nM
Compound 3: middle estimate off by 4.0-fold (0.60 log units), on the low side; the measured number lies above the stated range.
By their numbers in this assay, from the lowest: compound 2; then compounds 1 and 3 (each within the scatter of the next).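

With benzoyl or with 4-(diethylamino)benzyl on this nitrogen on an aromatic ring, the numbers in this assay cannot be told apart, the step being a 1.3-fold higher number from compound 1 to compound 3 (0.11 log units; within the scatter) on the core of compound 1. This position therefore holds either group, one with a carbonyl and the other with a diethylamino group and more heavy atoms, with no difference beyond the scatter. No measurement shown here bears on this result. The compounds shown leave open how a plain benzyl group or a benzyl group carrying a carboxylic acid would read at this nitrogen on this core.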